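The source may report more compounds than this note shows. Statements on the series, on what has been measured and on what is new or still open speak of the compounds shown alone.

Two compounds have so far been assessed in a functional assay on MT2 cells (Homo sapiens) for cytotoxicity; a lower number here means that less compound is tolerated, a higher number that more compound is tolerated. Compound 1 `COc1ccnc(Nc2ccc(Cl)c(OCC=C(C)C)c2)n1` gives 9000 nM in this assay, the lower of the two numbers; compound 2 `CCc1ccc(Nc2nccs2)cc1OCC=C(C)C` gives 31000 nM, a gap beyond the usual scatter. Compound 3 `CC(C)=CCOc1cc(Nc2nccc(N)n2)ccc1Cl` has not yet been measured. It differs from compound 1 by amino in place of methoxy on an aromatic carbon. For the measured compounds named here, no two measured compounds differ in a single place, so the size of this step cannot be read from the data; the change is expected to leave the result near that of compound 1, with no move beyond the scatter. Compound 3 is therefore expected to give 12000 nM in this assay, between 5000 nM and 30000 nM, an estimated step of a 1.3-fold higher number from compound 1 to compound 3 (0.12 log units; within the scatter).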

Compound 3, half-maximal cytotoxic concentration: 500 nM
Estimate against measurement, compound 3: 24-fold (1.38 log units) above; measured number outside the range, below it.
By their numbers in this assay, from the lowest: compound 3; then compound 1; then compound 2.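

Placing amino instead of methoxy on the aromatic carbon next to the ring nitrogen gives an 18-fold lower number from compound 1 to compound 3 (1.26 log units; beyond the scatter) in this assay. For the compounds shown here, this is the first single-place step, and it shows that the number is sensitive to the group at this position, with less compound tolerated when amino stands there. Nothing measured here bears on why the number moves. From the compounds shown here alone, it remains open whether a methylamino group, a hydroxyl group or a longer alkoxy chain at this position would give a similar step. Going by these compounds, it is also open whether amino would act the same way on the core of compound 2.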